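The source may hold more compounds than are shown below. What is called first, only, known or untested is meant among the compounds shown, and "the series" means these compounds.

Of the compounds shown here, three have been measured in a functional assay on NCI/ADR-RES cells (Homo sapiens) for inhibition, read by sulforhodamine B assay, with a stated time of 48 h, tested at 10 uM; a lower number here means less inhibition, a higher number more inhibition at the concentration tested (going by the name of the read-out). Compound 1 `O=Cc1ccc(-c2cn3ccnc3c(-c3ccc4ncn(C5CCCCC5)c4c3)n2)cc1` gives 37.4% in this assay. Compound 2 `c1ccc2c(-c3cn4ccnc4c(-c4ccc5ncn(C6CCCCC6)c5c4)n3)cccc2c1` gives 4.43% in this assay, and compound 3 `O=Cc1ccc(-c2cn3ccnc3c(-c3ccc4ncn(Cc5ccccc5)c4c3)n2)cc1` gives 37.4% in this assay.

Compound 2 differs from compound 1 in one place: naphthalen-1-yl in place of 4-formylphenyl on an aromatic carbon. That change made a step of a number 33 percentage points lower from compound 1 to compound 2 (beyond the scatter). Compound 3 differs from compound 1 in another place: benzyl in place of cyclohexyl on an aromatic nitrogen. That change made a step of no change at the digits printed from compound 1 to compound 3 (within the scatter), so compound 3 stands level with compound 1, the two together being the highest of the three numbers.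

Compound 4 `c1ccc(Cn2cnc3ccc(-c4nc(-c5cccc6ccccc56)cn5ccnc45)cc32)cc1` has not yet been measured in this assay. It differs from compound 3 by naphthalen-1-yl in place of 4-formylphenyl on an aromatic carbon. For the measured compounds named here, this is the same change, at a place described in the same words, as the one made from compound 1 to compound 2; the two cores differ by benzyl in place of cyclohexyl on an aromatic nitrogen. Because the step of a number 33 percentage points lower from compound 1 to compound 2 (beyond the scatter) was large and beyond the scatter, and because the step of no change at the digits printed from compound 1 to compound 3 (within the scatter) lay within the scatter, a step of about the same size is expected here, namely a number 32.4 percentage points lower from compound 3 to compound 4 (beyond the scatter). On that basis compound 4 is estimated to give 5% in this assay, with an expected range from -8% to 18%.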

Compound 4, a percentage reported as inhibition, at one concentration (the size of the read-out at that concentration, not a potency): 5.83%
Compound 4: the middle estimate sits 0.8 percentage points below what was measured; the range from low to high includes it.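

The new step in this assay is a number 31.6 percentage points lower from compound 3 to compound 4 (beyond the scatter), and it matches the one seen on the core of compound 1: the same change on two cores in this assay, a number 33 percentage points lower (beyond the scatter) from compound 1 to compound 2 and a number 31.6 percentage points lower (beyond the scatter) from compound 3 to compound 4, 1.4 percentage points apart, within the scatter of two such steps

The other change also held when carried across, with benzyl in place of cyclohexyl giving a number 1.4 percentage points higher from compound 2 to compound 4 (within the scatter), in line with what it did on the compounds bearing 4-formylphenyl: the same change on two cores in this assay, no change at the digits printed (within the scatter) from compound 1 to compound 3 and a number 1.4 percentage points higher (within the scatter) from compound 2 to compound 4, 1.4 percentage points apart, within the scatter of two such steps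

Within these four compounds, then, the two changes read as independent of each other, but this rests on only two groups at each of the two places, at a single concentration and in one cell line, so it does not show that the step would carry over to other cores or other groups, nor does it say what lies behind it.

Since naphthalen-1-yl differs from 4-formylphenyl both in losing the carbonyl and in gaining a second ring, the compounds shown leave open which of these goes with the step, a question that a plain phenyl, a 4-hydroxymethylphenyl or a 4-carboxyphenyl at that place would bear on. They also leave open whether the number in this assay would be higher, lower or level with other groups on the aromatic nitrogen, such as a longer alkyl chain or a chain ending in an amine.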